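The source may hold more compounds than are shown below. What is called first, only, known or untested is meant among the compounds shown, and "the series" means these compounds.

Measured in an ADME assay on microsomes from liver (Homo sapiens) for metabolic stability, with a stated time of 60 min, tested at 1 uM; a higher number here means that more of the compound is left, a lower number that less of the compound is left:
- Compound 1 `COc1cc(-c2cnn3cc(OC)c(C(C)C)nc23)ccn1`: 40%
- Compound 2 `Cn1cc(-c2nc3c(-c4ccnc(OC5CC5)c4)cnn3cc2OCCCC(C)(C)O)cn1`: 54%
- Compound 3 `COc1cn2ncc(-c3ccnc(OC4CC4)c3)c2nc1-c1cnn(C)c1`: 47%

Compound 1, at 40%, cannot be told apart from compound 3, at 47%, since the two lie within the usual scatter. Compound 2, at 54%, gives a higher number than compound 1, and that gap lies beyond the scatter.

Compound 4 `COc1cnc2c(-c3ccnc(OC)c3)cnn2c1` is the next to be tested, and it is compound 1 with one change: hydrogen in place of isopropyl on an aromatic carbon. In short, hydrogen takes the place of isopropyl on an aromatic carbon.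

Going by the values given here, only one measured step resembles this, in that a carbon group also gives way to hydrogen: a number 7 percentage points lower from compound 2 to compound 3 (within the scatter). That step lies within the scatter, but it is only a loose guide. It involves a different group at a different place, on a saturated chain carbon bound to an oxygen on an aromatic ring. Among the compounds with values here, no measured pair shows what losing the isopropyl does in this assay, so the forecast is uncertain.

The expected change is small and is estimated as a number 10 percentage points higher from compound 1 to compound 4 (within the scatter). For compound 4 the estimated value is 50%, with an expected range from 32% to 72%.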

Compound 4, percent of the compound remaining: 2%
Compound 4: middle estimate off by 48 percentage points, on the high side; measured number outside the range, below it.
By their numbers in this assay, from the lowest: compound 4; then compounds 1, 3 and 2 (each within the scatter of the next, the first and the last beyond it).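

In this assay, the isopropyl on this aromatic carbon, on the six-membered aromatic ring of the core, turns out to matter a great deal: putting hydrogen in its place gives a number 38 percentage points lower from compound 1 to compound 4 (beyond the scatter) as a large step. Going by these compounds alone, the earlier compounds could not show this, since their one step of this loose kind, at a saturated chain carbon bound to an oxygen on an aromatic ring, was a number 7 percentage points lower from compound 2 to compound 3 (within the scatter) and involved a different group at a different place. Nothing measured on these compounds explains why so little of compound 4 is left after the incubation, so the step stands as an observation only.

A methyl group, a cyclopropyl ring or an amine on the same aromatic carbon would help to show whether isopropyl itself is needed or whether a smaller group would keep the number up. From the compounds shown here alone, whether a drop of this size would also appear on going to hydrogen from compound 3, which carries a different group at this place, also stays open.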